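Methoxy for Methyl on a Weaker Core

This account rests on a few compounds, and the source may have more. Where it says the series, first, only, none or still open, it means among the compounds named here.

Measured in a functional assay on MCF7 cells (Homo sapiens) for inhibition, read by MTT assay, with a stated time of 48 h; on this read-out lower numbers stand for stronger inhibition and higher numbers for weaker inhibition:
Compound 1, `Cc1ccc(-n2cc(NC(=O)c3cccc(NS(=O)(=O)c4ccc(Cl)cc4)c3)cn2)cc1`: 1080 nM
Compound 2, `COc1ccc(-n2cc(NC(=O)c3cccc(NS(=O)(=O)c4ccc(Cl)cc4)c3)cn2)cc1`: 8720 nM
Compound 3, `Cc1ccc(-n2cc(NC(=O)c3ccc(NS(=O)(=O)c4ccccc4)cc3)cn2)cc1`: 10900 nM

Compound 1 and compound 2 differ in one place, (methoxy in place of methyl on an aromatic carbon), and this step gave an 8.1-fold higher number from compound 1 to compound 2 (0.91 log units; beyond the scatter). Compound 4, `COc1ccc(-n2cc(NC(=O)c3ccc(NS(=O)(=O)c4ccccc4)cc3)cn2)cc1`, has not yet been measured in this assay; it differs from compound 3 by methoxy in place of methyl on an aromatic carbon, the same change at the same kind of place. How the core of compound 3 differs from the core of compound 1 is not broken down here. Among the three measured numbers compound 3 gives the highest, though it lies within the scatter of compound 2.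

Because the same change earlier gave an 8.1-fold higher number from compound 1 to compound 2 (0.91 log units; beyond the scatter), compound 4 is expected to give a higher number than compound 3. The step is estimated as a 3.7-fold higher number from compound 3 to compound 4 (0.56 log units; beyond the scatter), somewhat smaller than the earlier one, as it rests on a single example and compound 3 already gives 10900 nM. The estimate for compound 4 is 40000 nM, between 12000 nM and 120000 nM.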

Compound 4, half-maximal inhibitory concentration: 25600 nM
The estimate for compound 4 lay 1.6-fold (0.19 log units) above the measured number, and the stated range covers the measured number.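

In this assay the change from 4-methylphenyl to 4-methoxyphenyl gave a 2.3-fold higher number from compound 3 to compound 4 (0.37 log units; beyond the scatter) and so ran in the same direction on both cores. Two pairs cannot show why the sizes differ, or whether the direction would hold on any other core in this series. The size of the step did not carry over from one core to the other: the same change on two cores in this assay, an 8.1-fold higher number (0.91 log units; beyond the scatter) from compound 1 to compound 2 and a 2.3-fold higher number (0.37 log units; beyond the scatter) from compound 3 to compound 4, 3.4-fold (0.54 log units) apart, beyond the scatter of two such steps

The compounds shown leave open how other groups at the same place would behave, such as an amine, a carboxylic acid or a longer chain like ethoxy. They also leave open which of the differences between the two cores goes with the gap in step size.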